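Furan-3-yl to pyridin-2-yl: notes on compound 4

The source may report more compounds than this note shows. Statements on the series, on what has been measured and on what is new or still open speak of the compounds shown alone.

For the measured compounds named here, in an ADME assay on Vero cells (Chlorocebus sabaeus) for cytotoxicity, read by MTT assay, with a stated time of 96 h (a lower number here means that less compound is tolerated, a higher number that more compound is tolerated), compound 3 `C/C(=N\NC(N)=S)c1ccc2c(c1)nc(-c1ccoc1)n2C1CCCCC1` gives 25000 nM, the only true number so far. Compound 1 `CC(=O)c1ccc2c(c1)nc(-c1ccccn1)n2C1CCCCC1` reads > 90000 nM, which is a limit. Compound 2 `C/C(=N\NC(N)=O)c1ccc2c(c1)nc(-c1ccccn1)n2C1CCCCC1` reads > 100000 nM, which is also a limit. Going by the values given here, the one measured step is a step that the two limits leave unreadable from compound 1 to compound 2. It concerns a different group and sets no size for the change considered here.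

Compound 4 `C/C(=N\NC(N)=S)c1ccc2c(c1)nc(-c1ccccn1)n2C1CCCCC1` differs from compound 3 at one place: pyridin-2-yl in place of furan-3-yl on an aromatic carbon. Among the compounds with values here, compounds 1 and 2 also carry pyridin-2-yl, but their limits provide no number to work from, and no measured step covers this exchange. The expectation therefore rests on compound 3 at 25000 nM, the only compound shown that shares the rest of the structure of compound 4. No change beyond the scatter in this assay is expected, and no direction can be assigned with confidence. The expected step is a 1.2-fold higher number from compound 3 to compound 4 (0.08 log units; within the scatter). For compound 4 the estimate is 30000 nM, with an expected range of 10000 nM to 90000 nM.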

Compound 4, half-maximal cytotoxic concentration: 20000 nM
Estimate against measurement, compound 4: 1.5-fold (0.18 log units) above, and the stated range covers the measured number.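

In this assay, a 1.3-fold lower number from compound 3 to compound 4 (0.10 log units; within the scatter), so with the rest of the structure held constant, pyridin-2-yl and furan-3-yl on this aromatic carbon between two ring nitrogen atoms cannot be told apart. With pyridin-2-yl fixed, the sulfur-bearing group in place of the oxygen-bearing group on the amine nitrogen gives an at least 5.0-fold lower number from compound 2 to compound 4 (0.69 log units; beyond the scatter), and the larger sulfur-bearing group in place of the smaller oxygen-bearing group on the aromatic carbon gives an at least 4.5-fold lower number from compound 1 to compound 4 (0.65 log units; beyond the scatter). Compounds 1 and 2 each read as a limit of the assay, and these two steps give only minimum sizes.

On these data alone, whether a phenyl group or a straight butyl chain at this position would also stay within the scatter of compound 3 remains open. As far as these compounds go, the full size of the two steps from the limits also remains open.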